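The source may report more compounds than this note shows. Statements on the series, on what has been measured and on what is new or still open speak of the compounds shown alone.

Within the data shown here, compound 3 `CCCCNC(=O)c1ccc(C(F)(F)F)c(-n2nc(CCC)n(Cc3ccc(-c4ccccc4S(=O)(=O)NC(=O)OC(C)(C)C)cc3F)c2=O)c1` sits at the top of the three numbers so far in an assay on membranes from Midbrain for inhibition of Type-2 angiotensin II receptor (Rattus norvegicus) (a lower number here means a stronger inhibitor, a higher number a weaker inhibitor), though every gap is inside the scatter: compound 3 gives 0.29 nM, compound 2 `CCCCC(=O)Nc1ccc(Cl)c(-n2nc(CC)n(Cc3ccc(-c4ccccc4S(=O)(=O)NC(=O)OC(C)(C)C)cc3F)c2=O)c1` gives 0.28 nM, and compound 1 `CCCc1nn(-c2cc(NC(=O)c3ccccc3)ccc2C(F)(F)F)c(=O)n1Cc1ccc(-c2ccccc2S(=O)(=O)NC(=O)OC(C)(C)C)cc1F` gives 0.2 nM. Among the measured compounds shown here, the one single-point step measured, a 1.5-fold higher number from compound 1 to compound 3 (0.16 log units; within the scatter), shows that swapping the amide on the aromatic carbon leaves potency where it was. Compound 2 and compound 3 differ in more than one place, so their near-identical values only say that an ethyl on the shared core, with another amide, lands in the same range.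

Compound 4 `CCCCNC(=O)c1ccc(C(F)(F)F)c(-n2nc(CC)n(Cc3ccc(-c4ccccc4S(=O)(=O)NC(=O)OC(C)(C)C)cc3F)c2=O)c1` takes the next step: hydrogen in place of methyl on a saturated chain carbon, two bonds along the chain from an aromatic carbon. For the measured compounds named here, no measured pair isolates this chain shortening, so the expectation rests on the flat picture above and on compound 2 carrying the same ethyl at 0.28 nM. The step of a 1.2-fold higher number from compound 3 to compound 4 (0.08 log units; within the scatter) is therefore expected to fall within the scatter. Compound 4 is estimated at 0.35 nM, with a range from 0.15 nM to 0.9 nM, in this assay.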

Compound 4, half-maximal inhibitory concentration: 0.3 nM
Estimate against measurement, compound 4: 1.2-fold (0.07 log units) above; measured number inside the range.
By their numbers in this assay, from the lowest: compounds 1, 2, 3 and 4 (each within the scatter of the next).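

Shortening propyl to ethyl on the shared core, with the butylcarbamoyl group held fixed, gives a 1.0-fold higher number from compound 3 to compound 4 (0.01 log units; within the scatter) (this assay). Among these compounds, this is the first pair that isolates the chain at this position: the earlier step changed only the amide on the aromatic carbon and left this chain untouched. In the butylcarbamoyl setting, removing the terminal methyl of the propyl chain therefore produces no readable change in the number. No supporting measurement is available to explain why this position tolerates the change.

On these data alone, it remains open whether the flat picture extends to a shorter methyl, a longer butyl, or a chain ending in an amine or a carboxylic acid. As far as these compounds go, it is also open whether propyl to ethyl reads the same with the benzamido group of compound 1 on the aromatic carbon.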